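A few compounds are considered here, and "the series" means these few. Any claim that something is new, unique, unknown or untested is made for them only; others in the source may bear on it.

Measured so far in an ADME assay on MDBK cells (Bos taurus) for cytotoxicity, read by MTT assay, with a stated time of 96 h; on this read-out lower numbers stand for higher toxicity in this test and higher numbers for lower toxicity in this test:
compound 1 `CN1CCN(CC(=O)Nc2ccc(-c3nc4cc(Cl)c(Cl)cc4[nH]3)cc2)CC1` gives 90000 nM;
compound 2 `Nc1ccc(-c2nc3cc(Cl)c(Cl)cc3[nH]2)cc1` gives 7500 nM;
compound 3 `Oc1ccc(-c2nc3cc(Cl)c(Cl)cc3[nH]2)cc1` gives 11000 nM.

Compound 2 stands lowest of the three numbers in this assay; compound 3 sits nearest, with a 1.5-fold higher number from compound 2 to compound 3 (0.17 log units; within the scatter), and compound 1 furthest, a gap beyond the scatter. Compound 4 `O=C(CN1CCCC1)Nc1ccc(-c2nc3cc(Cl)c(Cl)cc3[nH]2)cc1` is not yet measured. Its change from compound 2 is ((pyrrolidin-1-yl)methyl)carbonyl in place of hydrogen on a nitrogen on an aromatic ring. Within the data shown here, the only measured step, hydroxy for amino, does not touch this position and gives no guidance. What compound 1 and compound 2 show is that an acetamide-type substituent on this nitrogen goes with a markedly higher number. A step in the same direction is therefore expected, a 6.7-fold higher number from compound 2 to compound 4 (0.82 log units; beyond the scatter), though its size is uncertain. For compound 4 the estimate in this assay is 50000 nM, in the range 15000 nM to 150000 nM.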

Compound 4, half-maximal cytotoxic concentration: 16000 nM
For compound 4 the middle estimate is 3.1-fold (0.49 log units) above the measured one; measured number inside the range.
By their numbers in this assay, from the lowest: compounds 2, 3 and 4 (each within the scatter of the next, the first and the last beyond it); then compound 1.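

In this assay, ((pyrrolidin-1-yl)methyl)carbonyl in place of hydrogen on the nitrogen gives a 2.1-fold higher number from compound 2 to compound 4 (0.33 log units; beyond the scatter) as a modest step. With the carbonyl chain kept, pyrrolidin-1-yl in place of 4-methylpiperazin-1-yl gives a 5.6-fold lower number from compound 1 to compound 4 (0.75 log units; beyond the scatter) as the second step, so the number at this position depends on the terminal ring and not on the acyl link alone. Nothing available explains this dependence on the ring.

Open, going by these compounds, are morpholine, unsubstituted piperazine or an open-chain dimethylamino group on the same chain carbon. On these data alone, a longer chain between the carbonyl and the ring also remains open.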